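A few compounds are considered here, and "the series" means these few. Any claim that something is new, unique, unknown or untested is made for them only; others in the source may bear on it.

Measured so far in a functional assay on PC-3 cells (Homo sapiens) for cytotoxicity, read by MTT assay, with a stated time of 24 h; on this read-out higher numbers stand for weaker inhibition and lower numbers for stronger inhibition:

compound 1, `O=C1/C(=C/c2ccccc2F)CN(Cc2cn(Cc3ccccc3F)nn2)C/C1=C\c1ccccc1F`, gives 19700 nM.
compound 2, `O=C1/C(=C/c2ccccc2F)CN(Cc2cn(Cc3cccc(Cl)c3)nn2)C/C1=C\c1ccccc1F`, gives 6800 nM.
compound 3, `Cc1ccc(/C=C2\CN(C(=S)SCc3cn(Cc4cccc(Cl)c4)nn3)C/C(=C\c3ccc(C)cc3)C2=O)cc1`, gives only a limit of the assay, > 80000 nM.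

Compounds 1 and 2 share one core; compound 3 has another, and the difference between the two cores is not broken down here. Between compound 2 and compound 1 the change is 2-fluorophenyl in place of 3-chlorophenyl on a saturated chain carbon bound to an aromatic nitrogen, and in this assay it made a 2.9-fold higher number from compound 2 to compound 1 (0.46 log units; beyond the scatter), a modest step toward weaker inhibition.

Compound 4, `Cc1ccc(/C=C2\CN(C(=S)SCc3cn(Cc4ccccc4F)nn3)C/C(=C\c3ccc(C)cc3)C2=O)cc1`, has not yet been measured in this assay. It differs from compound 3 by 2-fluorophenyl in place of 3-chlorophenyl on a saturated chain carbon bound to an aromatic nitrogen, the same change at the same place as from compound 2 to compound 1. Since compound 3 already sits at the limit of > 80000 nM in this assay, at which 1 of the 3 values shown sits, and the earlier step went toward weaker inhibition, compound 4 is expected to remain at or beyond that limit; the estimated step is a step that the limit leaves unreadable from compound 3 to compound 4. The expected value for compound 4 in this assay is 150000 nM, with a range of 50000 nM to 500000 nM, most likely reported as a limit rather than a number.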

Compound 4, half-maximal inhibitory concentration: > 80000 nM
Compound 4 gave a limit, no number (the forecaster's own chance of this, stated with the estimate: 85%); the middle value does not contradict the limit.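

In this assay, compound 3 and compound 4 each gave a limit of the assay rather than a number, so no step can be read between them: the limit of > 80000 nM in this assay, at which 2 of the 4 values shown sit.

The compounds shown leave open whether 2-fluorophenyl in place of 3-chlorophenyl has any effect on the core of compound 3, as it did on the core of compound 2.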